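The source may hold more compounds than are shown below. What is called first, only, known or untested is meant among the compounds shown, and "the series" means these compounds.

Working notes on the series. Three chalcone-type compounds carry readings in a functional assay on MGC-803 cells (Homo sapiens) for inhibition, read by MTT assay, with a stated time of 72 h; on this read-out higher numbers stand for weaker inhibition and lower numbers for stronger inhibition: compound 1 `COc1cc(/C=C/C(=O)c2ccc(OCCCSC(=S)N3CCCC3)cc2)cc(OC)c1OC` gives 14500 nM, compound 2 `CN1CCN(C(=S)SCCCOc2ccc(C(=O)/C=C/c3cc(Cl)cc(Cl)c3)cc2)CC1` gives 19400 nM, and compound 3 `O=C(/C=C/c1ccc(Cl)cc1)c1ccc(OCCSC(=S)N2CCCCC2)cc1` gives 12800 nM. On these numbers compound 1 stands second highest of the three; its nearest neighbour is compound 3 and its furthest is compound 2, both within the scatter, so no order among the three is claimed. Compound 4 `COc1cc(/C=C/C(=O)c2ccc(OCCSC(=S)N3CCN(C)CC3)cc2)cc(OC)c1OC` is not yet measured in this assay. It differs from compound 1 by a group of 10 heavy atoms (6 carbon, 2 nitrogen, 2 sulfur; one six-membered non-aromatic ring with 2 hetero atoms) in place of a group of 9 heavy atoms (6 carbon, 1 nitrogen, 2 sulfur; one five-membered non-aromatic ring with 1 hetero atom), on a saturated chain carbon, two bonds along the chain from an oxygen on an aromatic ring. Within the data shown here, no measured pair in the set isolates that change, so the step from compound 1 to compound 4 is expected to stay within the scatter, with no clear direction; compound 2, which carries the six-membered ring with two hetero atoms, gives 19400 nM and offers no sign of a large shift. On that basis, compound 4 is estimated at 16000 nM, with a range of 7000 nM to 36000 nM, meaning an expected step of a 1.1-fold higher number from compound 1 to compound 4 (0.04 log units; within the scatter).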

Compound 4, half-maximal inhibitory concentration: 8280 nM
Compound 4: middle estimate off by 1.9-fold (0.29 log units), on the high side, and the stated range covers the measured number.
By their numbers in this assay, from the lowest: compounds 4, 3, 1 and 2 (each within the scatter of the next, the first and the last beyond it).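

In this assay the exchange on this saturated chain carbon gives a 1.8-fold lower number from compound 1 to compound 4 (0.24 log units; within the scatter) and so the six-membered non-aromatic ring with 2 hetero atoms is tolerated here in place of the five-membered non-aromatic ring with 1 hetero atom. Among these compounds, this is the first pair in the set that reads a change at this position directly, and it shows no shift beyond the scatter. From the compounds shown here alone, how a morpholine ring or a longer chain would read at this place stays open, as does whether the step holds on the cores of compound 2 and compound 3. No evidence on a cause for this step is at hand.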